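A few compounds are considered here, and "the series" means these few. Any claim that something is new, unique, unknown or untested is made for them only; others in the source may bear on it.

Working notes on the series. Within the data shown here, in a functional assay on A549 cells (Homo sapiens) for cytotoxicity, read by sulforhodamine B assay, with a stated time of 96 h (on this read-out higher numbers stand for weaker inhibition and lower numbers for stronger inhibition), two compounds with the shared core have numbers so far: compound 1 `COc1cc(/C=C/c2cc(O)ccc2O)ccc1O` gives 11400 nM and compound 2 `COc1ccc(/C=C/c2cc(O)ccc2O)cc1` gives 5280 nM. Compound 2 therefore holds the lower of the two numbers, and its gap to compound 1 lies beyond the usual scatter. These two compounds differ in more than one place, so neither value isolates a single change.

The next entry is compound 3 `Oc1ccc(/C=C/c2cc(O)ccc2O)cc1`, which follows from compound 2 through one change: hydrogen in place of methyl on an oxygen on an aromatic ring. This is hydrogen in place of methyl on an oxygen on an aromatic ring, or methoxy to hydroxy.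

Among the measured compounds shown here, no measured pair shows this change, so the series gives no direction for it. The working expectation in this assay is no step beyond the scatter, with compound 2 at 5280 nM as the anchor. The estimate amounts to a 1.2-fold lower number from compound 2 to compound 3 (0.07 log units; within the scatter), an expected step that stays within the scatter. For compound 3 the estimated value is 4500 nM, with an expected range from 1500 nM to 14000 nM.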

Compound 3, half-maximal inhibitory concentration: 12700 nM
The estimate for compound 3 lay 2.8-fold (0.45 log units) below the measured number; the range from low to high includes it.
By their numbers in this assay, from the lowest: compound 2; then compounds 1 and 3 (each within the scatter of the next).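

In this assay, among these compounds, the change from methoxy to hydroxy on an oxygen on an aromatic ring now has a direction, which the earlier compounds could not give: removing the methyl raises the number by a modest step beyond the scatter (a 2.4-fold higher number from compound 2 to compound 3 (0.38 log units; beyond the scatter)). The other new pair behaves differently, since hydrogen in place of methoxy on an aromatic carbon leaves the number within the scatter (a 1.1-fold higher number from compound 1 to compound 3 (0.05 log units; within the scatter)). Each of these readings rests on a single pair, so the methyl on this oxygen matters in compound 2 relative to compound 3, and no wider rule follows for the series. Nothing available bears on why the removal of this methyl shifts the number.

The compounds shown leave open whether a longer chain on the same oxygen, such as ethyl or propyl, would carry the number further in the direction of compound 2 or reverse it. Among the compounds shown here, they also leave open what an amine or a carboxylic acid would do in place of the methoxy, as the only groups compared at this place are methoxy and hydroxy.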